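Shortening a Selenium-Bearing Chain on Compound 1

The source may report more compounds than this note shows. Statements on the series, on what has been measured and on what is new or still open speak of the compounds shown alone.

Measured compounds:
compound 1, `COc1ccc(N(C)c2nc(C)nc3ccccc23)cc1OCCCCCC[Se]C#N`, 5520 nM
compound 2, `Cc1nc(N(C)c2ccc(OCC[Se]C#N)cc2)c2ccccc2n1`, 893 nM
compound 3, `C[Se]c1ccc(N(C)c2nc(C)nc3ccccc23)cc1Cl`, 2 nM

Of the compounds shown here, three sharing one core have been tested in a functional assay on A549 cells (Homo sapiens) for inhibition, read by MTT assay, with a stated time of 48 h; a lower number here means a stronger inhibitor, a higher number a weaker inhibitor. Compound 1 gives 5520 nM, the highest of the three numbers, so it is the weakest inhibitor of the set. The nearest to it is compound 2, which gives 893 nM, a gap that lies beyond the usual scatter. The furthest is compound 3, which gives 2 nM, a gap far beyond the scatter. Compound 2 and compound 3 each differ from compound 1 in more than one place, so no single change can be read from those two gaps.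

Compound 4, `COc1ccc(N(C)c2nc(C)nc3ccccc23)cc1OCCCCC[Se]C#N`, has not yet been measured. It differs from compound 1 in one place only: a group of 3 heavy atoms (1 carbon, 1 nitrogen, 1 selenium; no ring) in place of a group of 4 heavy atoms (2 carbon, 1 nitrogen, 1 selenium; no ring), on a saturated chain carbon, five bonds along the chain from an oxygen on an aromatic ring. The chain that carries the selenium thus becomes shorter while everything else on the core stays the same. Among the measured compounds shown here, the measured set contains no pair that isolates a change of this kind, so no firm direction can be drawn. A small step is expected, a 1.4-fold lower number from compound 1 to compound 4 (0.14 log units; within the scatter), toward a slightly lower number or none beyond the scatter. Compound 4 is therefore expected to give about 4000 nM, within a range from 1500 nM to 12000 nM.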

Compound 4, half-maximal inhibitory concentration: 2440 nM
For compound 4 the middle estimate is 1.6-fold (0.21 log units) above the measured one, within the range that was stated.
By their numbers in this assay, from the lowest: compound 3; then compound 2; then compound 4; then compound 1.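

Among the compounds shown here, this pair is the first in the set to differ in one place only, so the length of the chain carrying the selenium can now be read on its own. In this assay, the group of 3 heavy atoms in place of the group of 4 heavy atoms, on a saturated chain carbon, five bonds along the chain from an oxygen on an aromatic ring, gives a 2.3-fold lower number from compound 1 to compound 4 (0.35 log units; beyond the scatter). The step is modest, but it shows that this chain length has a measurable effect on the number and that the shorter chain is the stronger inhibitor of the two, though nothing measured here accounts for that difference.

As far as these compounds go, a single step gives a direction between two chain lengths, not a trend, so it remains open whether a still shorter chain would lower the number further or a longer chain would raise it further. The compounds shown also leave open what would happen at the end of this chain if the selenium were replaced by sulfur, or if an amine or a carboxylic acid took the place of the selenium-bearing end.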